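The source may hold more compounds than are shown below. What is called first, only, known or untested is meant among the compounds shown, and "the series" means these compounds.

Measured so far in an assay on cells for displacement of a labelled ligand from Orexin/Hypocretin receptor type 1 (Homo sapiens), read by scintillation counting, with stated times of 10 min and 90 min, tested at 10 uM; on this read-out lower numbers stand for less inhibition and higher numbers for more inhibition at the one concentration tested (going by the name of the read-out):
Compound 1 `COC(=O)c1ccc2ccc(C(=O)c3ccccc3)c-2cc1` gives 7.2%.
Compound 2 `O=C(O)c1ccc2ccc(C(=O)c3ccccc3)c-2cc1` gives 11%.
Compound 3 `COC(=O)c1ccc2ccc(C=O)c-2cc1` gives 25%.

Compound 3 stands highest of the three, and both of its gaps to the others lie beyond the usual scatter of repeated measurements. It arose from compound 1 by a number 17.8 percentage points higher from compound 1 to compound 3 (beyond the scatter), a modest rise.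

Compound 4 `O=Cc1ccc2ccc(C(=O)O)ccc1-2` is the next compound, and it differs from compound 3 by hydrogen in place of methyl on an oxygen next to a carbonyl group.

Going by the values given here, one measured step bears directly on this change: the same swap, hydrogen in place of methyl on an oxygen next to a carbonyl group, was made between compound 1 and compound 2, and it gave a number 3.8 percentage points higher from compound 1 to compound 2 (within the scatter). That step lay within the scatter, so there is no sign that this change moves the read-out in this assay on this core. The expectation for compound 4 is therefore no step beyond the scatter, expressed as a number 2 percentage points higher from compound 3 to compound 4 (within the scatter). Compound 4 is expected to give about 27% in this assay, with a range from 14% to 40%.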

Compound 4, a percentage reported as inhibition, at one concentration (the size of the read-out at that concentration, not a potency): 37.8%
The estimate for compound 4 lay 10.8 percentage points below the measured number; the measured number falls inside the stated range.
By their numbers in this assay, from the lowest: compounds 1 and 2 (each within the scatter of the next); then compound 3; then compound 4.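

On the core with hydrogen on the carbonyl carbon, going from methoxycarbonyl to carboxy gives a number 12.8 percentage points higher from compound 3 to compound 4 (beyond the scatter) in this assay, the first time this swap has produced a step beyond the scatter. Even so, the data do not show that the swap acts differently on the two cores: the same change on two cores in this assay, a number 3.8 percentage points higher (within the scatter) from compound 1 to compound 2 and a number 12.8 percentage points higher (beyond the scatter) from compound 3 to compound 4, 9 percentage points apart, within the scatter of two such steps Hydrogen in place of phenyl on a carbonyl carbon now also gives a step beyond the scatter with carboxy present, a number 26.8 percentage points higher from compound 2 to compound 4 (beyond the scatter), and its size holds across the two cores: the same change on two cores in this assay, a number 17.8 percentage points higher (beyond the scatter) from compound 1 to compound 3 and a number 26.8 percentage points higher (beyond the scatter) from compound 2 to compound 4, 9 percentage points apart, within the scatter of two such steps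

The compounds shown leave open how an amide in place of the carboxy group, or a small alkyl group such as ethyl in place of the hydrogen on the carbonyl carbon, would read. Each number comes from a single concentration, so none of them gives a potency.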